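Working notes: hydroxy to methoxy on compound 2

The source may report more compounds than this note shows. Statements on the series, on what has been measured and on what is new or still open speak of the compounds shown alone.

Measured so far in an ADME assay on MCF7 cells (Homo sapiens) for cytotoxicity; on this read-out higher numbers stand for weaker inhibition and lower numbers for stronger inhibition:
compound 1 `Oc1cc(O)cc(CCCCCCCCCCCCCCc2cc(O)cc(O)c2)c1` gives 29200 nM
compound 2 `Oc1cc(O)cc(CCCCC/C=C/CCCCCCCc2cc(O)cc(O)c2)c1` gives 28600 nM
compound 3 `Oc1cc2cc(c1)Oc1c(O)cc(cc1O)CCCCCCC/C=C/CCCCC2` gives 31800 nM

Compound 2 stands within the scatter of both compound 1 and compound 3, so these three values form a single level. For the measured compounds named here, no measured pair differs in one place only, so the series gives no direct measure of any single structural change.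

The next case is compound 4 `COc1cc(O)cc(CCCCCCC/C=C/CCCCCc2cc(O)cc(O)c2)c1`. Relative to compound 2 it carries methyl in place of hydrogen on an oxygen on an aromatic ring, which is methyl in place of hydrogen on an oxygen on an aromatic ring, or hydroxy to methoxy.

With only this level to go on, set by compound 2 at 28600 nM, no step beyond the scatter is expected in this assay, in either direction. The estimated 1.0-fold higher number from compound 2 to compound 4 (0.02 log units; within the scatter) is expected to stay within the scatter. For compound 4 the estimated value is 30000 nM, with an expected range from 15000 nM to 60000 nM.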

Compound 4, half-maximal inhibitory concentration: 29800 nM
Compound 4: middle estimate off by 1.0-fold (0.00 log units), on the high side; the range from low to high includes it.
By their numbers in this assay, from the lowest: compounds 2, 1, 4 and 3 (each within the scatter of the next).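

In this assay the series now has its first comparison in one place: hydroxy to methoxy, turning 3,5-dihydroxyphenyl into 3-hydroxy-5-methoxyphenyl, gives a 1.0-fold higher number from compound 2 to compound 4 (0.02 log units; within the scatter) and so leaves compound 4 on the level of compound 2. For the compounds shown here, at this position, methyl in place of hydrogen on an oxygen on an aromatic ring therefore produces no step beyond the scatter, a result that the earlier compounds, with no single-place pair among them, could not give. Nothing available explains why the step stays this small.

Still open, from the compounds shown here alone, is whether a longer chain on the same oxygen, or an amine or carboxylic acid in place of the hydroxy group, would stay on this level. Going by these compounds, it is equally open whether methoxy on the remaining hydroxy positions would leave the number within the scatter.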